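Trifluoromethyl Added to the Phenyl Ring of an EP4 Agonist

A few compounds are considered here, and "the series" means these few. Any claim that something is new, unique, unknown or untested is made for them only; others in the source may bear on it.

Measured so far:
Compound 1, `O=C(O)CCCSCCN1C(=O)OC[C@@H]1/C=C/[C@@H](O)Cc1ccccc1`: 36 nM
Compound 2, `CCCc1cccc(C[C@H](O)/C=C/[C@H]2CCC(=S)N2CCCCCCC(=O)O)c1`: 27 nM

Of the compounds shown here, two have been tested in a functional assay on CHO cells for agonist activity at prostaglandin E2 receptor EP4 subtype (Rattus norvegicus), read by cAMP accumulation and immunoassay, with a stated time of 10 min; a higher number here means that more compound is needed for the effect, a lower number that less compound is needed. Compound 1 gives 36 nM, and compound 2 gives 27 nM. Within the data shown here, these two numbers lie within the scatter of each other, so neither compound can be set apart from the other on this basis; the series so far shows nothing about how changes on the phenyl ring move the read-out.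

Compound 3, `O=C(O)CCCSCCN1C(=O)OC[C@@H]1/C=C/[C@@H](O)Cc1cccc(C(F)(F)F)c1`, is not yet measured. It differs from compound 1 in one place: trifluoromethyl in place of hydrogen on an aromatic carbon. Among the measured compounds shown here, since no measured pair shows this change, its effect can only be guessed. The expectation is that the step of a 1.6-fold lower number from compound 1 to compound 3 (0.21 log units; within the scatter) stays within the scatter, with no more than a slight lean toward a lower number. Compound 3 is therefore expected to give 22 nM, within a range from 6 nM to 80 nM.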

Compound 3, half-maximal effective concentration: 12 nM
Estimate against measurement, compound 3: 1.8-fold (0.26 log units) above; measured number inside the range.
By their numbers in this assay, from the lowest: compound 3; then compounds 2 and 1 (each within the scatter of the next).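

In this assay, among these compounds, trifluoromethyl in place of hydrogen on the phenyl ring gives a 3.0-fold lower number from compound 1 to compound 3 (0.48 log units; beyond the scatter), the first change that can be read as a real shift. It shows that this place on the ring, meta to a large group, accepts a group of four heavy atoms in place of a lone hydrogen, and that less compound is then needed for the effect. Compound 1 and compound 2 differ in more than one place, so they could not show this, and nothing measured here explains the shift.

Still open, as far as these compounds go, is whether a chlorine atom, a methoxy group or a nitrile at this same place would move the number as far, or further. Also open, from the compounds shown here alone, is whether trifluoromethyl would have the same effect elsewhere on the ring, or on the core of compound 2.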